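The source may hold more compounds than are shown below. What is called first, only, known or untested is meant among the compounds shown, and "the series" means these compounds.

Measured so far in a functional assay on DU-145 cells (Homo sapiens) for inhibition, read by trypan blue exclusion, with a stated time of 96 h; on this read-out lower numbers stand for stronger inhibition of growth and higher numbers for weaker inhibition of growth: compound 1 `O=C(/C(=C\c1ccc([N+](=O)[O-])c(O)c1)SCc1ccc(Br)cc1)c1ccc(Br)cc1` gives 10000 nM; compound 2 `O=C(/C(=C\c1ccc(O)c([N+](=O)[O-])c1)S(=O)(=O)c1ccc(I)cc1)c1ccc(Br)cc1` gives 25000 nM; compound 3 `O=C(/C(=C\c1ccc(O)c([N+](=O)[O-])c1)Sc1ccc(Br)cc1)c1ccc(Br)cc1` gives 1000 nM.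

Compound 3 stands lowest of the three numbers; its nearest neighbour is compound 1 and its furthest is compound 2. Going by the values given here, the one single-point step recorded, a 25-fold lower number from compound 2 to compound 3 (1.40 log units; beyond the scatter), concerns the sulfur-linked group on the double-bonded chain carbon, and it was large.

Compound 4 `O=C(/C(=C\c1ccc(O)c([N+](=O)[O-])c1)SCc1ccc(Br)cc1)c1ccc(Br)cc1` carries the change (4-bromobenzyl in place of 4-bromophenyl on a sulfur). Among the compounds with values here, no measured step covers this change directly. Compound 1, which carries the same 4-bromobenzyl on sulfur but a different arrangement of the phenol ring, sits well above compound 3, so for compound 4 a step upward, beyond the scatter, is expected: a 5.0-fold higher number from compound 3 to compound 4 (0.70 log units; beyond the scatter). The estimate for compound 4 is 5000 nM, in the range 1500 nM to 15000 nM.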

Compound 4, concentration for 50% growth inhibition: 10000 nM
Estimate against measurement, compound 4: 2.0-fold (0.30 log units) below; measured number inside the range.
By their numbers in this assay, from the lowest: compound 3; then compounds 1 and 4 (each within the scatter of the next); then compound 2.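

Replacing 4-bromophenyl with 4-bromobenzyl on the sulfur weakens growth inhibition in a directly matched pair (a 10-fold higher number from compound 3 to compound 4 (1.00 log units; beyond the scatter)). With 4-bromobenzyl on the sulfur, 4-hydroxy-3-nitrophenyl and 3-hydroxy-4-nitrophenyl are not told apart (no change at the digits printed from compound 1 to compound 4 (within the scatter)). The (4-bromobenzyl)sulfanyl group still gives stronger inhibition than (4-iodophenyl)sulfonyl (a 2.5-fold lower number from compound 2 to compound 4 (0.40 log units; beyond the scatter)).

Open, on these data alone, are a longer chain, such as 2-phenylethyl, on the sulfur and the effect of 3-hydroxy-4-nitrophenyl with 4-bromophenyl on the sulfur. No supporting data explain these steps.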